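A few compounds are considered here, and "the series" means these few. Any claim that something is new, unique, unknown or untested is made for them only; others in the source may bear on it.

In a functional assay on MDA-MB-231 cells (Homo sapiens) for cytotoxicity, read by MTT assay, with a stated time of 48 h (on this read-out higher numbers stand for an effect only at larger amounts of compound and lower numbers for an effect already at smaller amounts), compound 2 (`CO[C@H]1O[C@H](COc2ccc(-c3ccccc3)cc2)[C@@H](O)[C@H](O)[C@H]1Oc1ccc(C(C)C)cc1`) gives 31000 nM and compound 1 (`CO[C@H]1O[C@H](COc2ccc3c(c2)CCCC3)[C@@H](O)[C@H](O)[C@H]1Oc1ccc(OC2CCCCC2)cc1`) gives 20000 nM within the scatter of it, while compound 3 (`CO[C@H]1O[C@H](COc2ccc(C3CCCCC3)cc2)[C@@H](O)[C@H](O)[C@H]1Oc1ccc(OC2CCCCC2)cc1`) gives 14000 nM as a number lower than that of compound 2 beyond the scatter. Compound 4 (`CO[C@H]1O[C@H](COc2ccc(-c3ccccc3)cc2)[C@@H](O)[C@H](O)[C@H]1Oc1ccccc1C(C)C`) differs from compound 2 by 2-isopropylphenyl in place of 4-isopropylphenyl on an oxygen on a saturated carbon with 2-isopropylphenyl in place of 4-isopropylphenyl on an oxygen on a saturated carbon. Among the compounds with values here, the one measured step (a 1.4-fold lower number from compound 1 to compound 3 (0.15 log units; within the scatter)) stays within the scatter, but it exchanges a different group, and no measured step moves an isopropyl group. No step beyond the scatter is therefore expected in this assay for this change. The expected step (a 1.2-fold lower number from compound 2 to compound 4 (0.08 log units; within the scatter)) is accordingly small. For compound 4 the estimate is 26000 nM (12000 nM to 55000 nM).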

Compound 4, half-maximal effective concentration: 34000 nM
The estimate for compound 4 lay 1.3-fold (0.12 log units) below the measured number; the range from low to high includes it.
By their numbers in this assay, from the lowest: compounds 3, 1, 2 and 4 (each within the scatter of the next, the first and the last beyond it).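

In this assay, 2-isopropylphenyl in place of 4-isopropylphenyl on an oxygen on a saturated carbon gives a 1.1-fold higher number from compound 2 to compound 4 (0.04 log units; within the scatter). This is the only step shown at this place, and it shows that the two groups, with the same atoms joined differently, cannot be told apart here. Nothing available offers an explanation for this result. On these data alone, whether an amine or a carboxylic acid in place of the isopropyl group would move the number beyond the scatter remains open. Also open, as far as these compounds go, is whether this exchange stays as small with another group elsewhere on the shared core.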